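The source may report more compounds than this note shows. Statements on the series, on what has been measured and on what is new or still open speak of the compounds shown alone.

Measured so far in a functional assay on NIH3T3 cells (Mus musculus); on this read-out higher numbers stand for an effect only at larger amounts of compound and lower numbers for an effect already at smaller amounts:
- compound 1 `Cn1cncc1C(OCc1ccc(C#N)cc1-c1cccc2ccccc12)c1ccc(C#N)nc1`: 46 nM
- compound 2 `Cn1cncc1C(OCc1nc(N2CCC(C(N)=O)CC2)c(C#N)cc1-c1cccc(Cl)c1)c1ccc(C#N)cc1`: 1.5 nM

Compound 1 stands at the higher of the two numbers, and the gap down to compound 2 lies beyond the scatter. Going by the values given here, the two compounds differ in more than one place, so the series has no measured single-place step yet.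

The next compound is compound 3 `Cn1cncc1C(OCc1ccc(C#N)cc1-c1cccc(OC(F)(F)F)c1)c1ccc(C#N)nc1`, which differs from compound 1 as follows: 3-(trifluoromethoxy)phenyl in place of naphthalen-1-yl on an aromatic carbon. It has 3-(trifluoromethoxy)phenyl in place of naphthalen-1-yl, on an aromatic carbon ortho to a large group and meta to a cyano group.

No measurement shows what this exchange does in this assay. Compound 2 reaches 1.5 nM without a naphthalen-1-yl group, so losing that group is not expected to raise the number much, although this is weak guidance given its other differences. No step beyond the scatter is expected, and the estimate is a 1.5-fold lower number from compound 1 to compound 3 (0.19 log units; within the scatter). For compound 3 the expected value is 30 nM, with an estimated range of 8 nM to 120 nM.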

Compound 3, half-maximal effective concentration: 24 nM
Compound 3: middle estimate off by 1.3-fold (0.10 log units), on the high side; measured number inside the range.
By their numbers in this assay, from the lowest: compound 2; then compounds 3 and 1 (each within the scatter of the next).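

In this assay, going by these compounds alone, the exchange of naphthalen-1-yl for 3-(trifluoromethoxy)phenyl, on an aromatic carbon ortho to a large group and meta to a cyano group, gives a 1.9-fold lower number from compound 1 to compound 3 (0.28 log units; within the scatter) and is the first single-place step. At this position, the read-out therefore does not separate a group of two six-membered aromatic rings from one of a single such ring with a trifluoromethoxy substituent, even though the entering group brings a hydrogen-bond acceptor and the leaving group has none. Nothing measured on these compounds accounts for this result.

The compounds shown leave open whether the trifluoromethoxy substituent contributes at all, since plain phenyl, 3-methoxyphenyl and a phenyl ring bearing a carboxylic acid or an amine are not among them, and neither is a small alkyl group such as methyl at this carbon. They also leave open whether this tolerance carries over to the core of compound 2, and no single place can yet be tied to the gap between that compound and the other two.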